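This account rests on a few compounds, and the source may have more. Where it says the series, first, only, none or still open, it means among the compounds named here.

Three members of a shared core have been measured in a functional assay on MDA-MB-231 cells (Homo sapiens) for cytotoxicity, read by MTT assay, with a stated time of 48 h; on this read-out higher numbers stand for weaker inhibition and lower numbers for stronger inhibition. Compound 1 `O=C(/C=C/c1ccc2c(c1)B(O)OC2)c1ccccc1` gives 2300 nM. Compound 2 `O=C(/C=C/c1ccc2c(c1)B(O)OC2)c1ccc(-c2ccccc2)cc1` gives 6400 nM, and compound 3 `O=C(/C=C/c1ccc2c(c1)B(O)OC2)c1ccc(I)cc1` gives 14900 nM. Compound 2 thus stands second highest of the three numbers: its nearest neighbour is compound 3, with the step of a 2.3-fold higher number from compound 2 to compound 3 (0.37 log units; beyond the scatter), and its furthest is compound 1, with the step of a 2.8-fold higher number from compound 1 to compound 2 (0.44 log units; beyond the scatter). The remaining measured step, a 6.5-fold higher number from compound 1 to compound 3 (0.81 log units; beyond the scatter), runs in the same direction.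

Compound 4 `O=C(/C=C/c1ccc2c(c1)B(O)OC2)c1ccc(C(F)(F)F)cc1` differs from compound 2 in one place: trifluoromethyl in place of phenyl on an aromatic carbon. Within the data shown here, two measured steps bear on this exchange. Phenyl in place of hydrogen on the aromatic carbon gave a 2.8-fold higher number from compound 1 to compound 2 (0.44 log units; beyond the scatter), and iodo in place of hydrogen gave the larger step of a 6.5-fold higher number from compound 1 to compound 3 (0.81 log units; beyond the scatter); iodo in place of phenyl gave a 2.3-fold higher number from compound 2 to compound 3 (0.37 log units; beyond the scatter). Each group measured at this carbon so far has raised the number relative to hydrogen, and the trifluoromethyl, which brings no ring, is closer in kind to the iodo than to the phenyl. The step from compound 2 to compound 4 is therefore expected to be modest and upward, a 1.6-fold higher number from compound 2 to compound 4 (0.19 log units; within the scatter). Compound 4 is estimated at 10000 nM in this assay, with a range from 4000 nM to 25000 nM.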

Compound 4, half-maximal inhibitory concentration: 9200 nM
Beside the measured number, compound 4's estimate is 1.1-fold (0.04 log units) above it; measured number inside the range.
By their numbers in this assay, from the lowest: compound 1; then compounds 2, 4 and 3 (each within the scatter of the next, the first and the last beyond it).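

In this assay, trifluoromethyl on this aromatic carbon cannot be told apart from either of the two larger groups already measured there: a 1.4-fold higher number from compound 2 to compound 4 (0.16 log units; within the scatter) and a 1.6-fold lower number from compound 3 to compound 4 (0.21 log units; within the scatter) both lie within the scatter, even though compound 2 and compound 3 lie beyond the scatter of each other. Against hydrogen the change is clearer, with a 4.0-fold higher number from compound 1 to compound 4 (0.60 log units; beyond the scatter) lying beyond the scatter, so a group with no ring and with fluorine in it now joins phenyl and iodo in giving a higher number than hydrogen, and none of the compounds shown goes against this. No measurement shown explains why these three different groups behave alike here.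

Whether any group on this carbon can match or lower the number given by hydrogen in compound 1 remains open, as the compounds shown include no amine, hydroxyl, methoxy or carboxylic acid there. On these data alone, it is also open whether the same changes would have a similar outcome on another carbon of this ring, since all of these groups stand para to a large group.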